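Removing the Ethyl Group: An Expectation for Compound 4

A few compounds are considered here, and "the series" means these few. Any claim that something is new, unique, unknown or untested is made for them only; others in the source may bear on it.

Measured so far:
- Compound 1, `Cc1ccc(NC2=CC(=O)c3nc4n(c3C2=O)[C@H]2OC[C@@H](O)[C@H]2OC4)cc1C`: in a functional assay on MCF7 cells (Homo sapiens) for inhibition, read by sulforhodamine B assay (on this read-out higher numbers stand for weaker inhibition and lower numbers for stronger inhibition), compound 1 gives 2080 nM.
- Compound 2, `COc1cccc(NC2=CC(=O)c3nc4n(c3C2=O)[C@H]2OC[C@@H](O)[C@H]2OC4)c1`: in this assay compound 2 gives > 4000 nM, which is a limit of the assay rather than a number.
- Compound 3, `CCc1ccc(NC2=CC(=O)c3nc4n(c3C2=O)[C@H]2OC[C@@H](O)[C@H]2OC4)cc1`: in this assay compound 3 gives 960 nM.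

Among the numbers shown, compound 3 has the lowest, and its nearest neighbour is compound 1, from which the step of a 2.2-fold lower number from compound 1 to compound 3 (0.34 log units; beyond the scatter) lies beyond the scatter. Compound 2 gives only (the limit of > 4000 nM in this assay, at which 1 of the 3 values shown sits), so no number exists for it.

Compound 4, `O=C1C=C(Nc2ccccc2)C(=O)c2c1nc1n2[C@H]2OC[C@@H](O)[C@H]2OC1`, has not yet been measured. It differs from compound 3 in one place: hydrogen in place of ethyl on an aromatic carbon. Within the data shown here, two measured steps bear on this change, since both bring the 4-ethylphenyl group in: a 2.2-fold lower number from compound 1 to compound 3 (0.34 log units; beyond the scatter) and an at least 4.1-fold lower number from compound 2 to compound 3 (0.61 log units; beyond the scatter). In each case the compound carrying 4-ethylphenyl gave the lower number. Compound 4 removes that group altogether, leaving anilino, so in this assay its number is expected to rise by roughly a 2.6-fold higher number from compound 3 to compound 4 (0.42 log units; beyond the scatter), towards weaker inhibition. Among the measured compounds shown here, no measured compound carries a plain phenyl, which leaves the size uncertain. Compound 4 is therefore estimated at 2500 nM, with a range from 1000 nM to 6000 nM.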

Compound 4, half-maximal inhibitory concentration: > 4000 nM
Compound 4 was reported as a limit (the forecaster's own chance of this, stated with the estimate: 25%); middle value at least 1.6-fold (0.20 log units) away from the limit.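

In this assay, among these compounds, the pair of compound 3 and compound 4 is the first to isolate the ethyl group on this aromatic carbon, para to a large group, and replacing it with hydrogen gives an at least 4.1-fold higher number from compound 3 to compound 4 (0.61 log units; beyond the scatter), so the gain seen with 4-ethylphenyl does not survive its removal. Against the dimethyl-substituted compound, the change to plain phenyl gives an at least 1.9-fold higher number from compound 1 to compound 4 (0.28 log units; that floor lies within the scatter), so this floor alone does not separate the two compounds. The step between compound 2 and compound 4 cannot be read, because both sit at a limit of the assay rather than at a number: the limit of > 4000 nM in this assay, at which 2 of the 4 values shown sit.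

The direct comparison at this position covers only ethyl and hydrogen, so a longer chain such as propyl, or an amine or a carboxylic acid on the same carbon, remains an open case. As far as these compounds go, how far compound 4 lies past its limit is also open, and with it the full size of the step from ethyl to hydrogen.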